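Second chloro on the fused core of a benzyl series

A few compounds are considered here, and "the series" means these few. Any claim that something is new, unique, unknown or untested is made for them only; others in the source may bear on it.

Measured so far in a functional assay on RXF 393 cells (Homo sapiens) for cytotoxicity, read by sulforhodamine B assay, with a stated time of 48 h; a lower number here means that less compound is tolerated, a higher number that more compound is tolerated:
compound 1 `ClCc1ccc(Cn2cnc3c(Cl)ncnc32)cc1` gives > 100000 nM
compound 2 `ClCc1ccc(Cn2cnc3nc(Cl)nc(Cl)c32)cc1` gives "not determined" (no result reported)
compound 3 `ClCc1cccc(Cn2cnc3c(Cl)nc(Cl)nc32)c1` gives 5120 nM

Compound 1 stands only at a limit in this assay, > 100000 nM, which is the limit itself and not a number (the limit of > 100000 nM in this assay, at which 1 of the 3 values shown sits). Compound 2 has no reported result. Going by the values given here, compound 3, which carries two chloro groups on its fused core, is the only member with a numerical value, 5120 nM.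

Compound 4 `ClCc1ccc(Cn2cnc3c(Cl)nc(Cl)nc32)cc1` is not yet measured. It differs from compound 1 by chloro in place of hydrogen on an aromatic carbon. Among the compounds with values here, no measured pair isolates this change, so the expected size of the step is read only from what compounds 1 and 3 show.

Since compound 3 gives 5120 nM, compound 4 is expected to reach a measurable value. Compound 4 is estimated at 9000 nM, with a range from 2500 nM to 60000 nM. The expected step is an at least 11-fold lower number from compound 1 to compound 4 (1.04 log units; beyond the scatter), though a limit remains possible.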

Compound 4, concentration lethal to 50% of the cells: 83200 nM
Beside the measured number, compound 4's estimate is 9.2-fold (0.97 log units) below it; measured number above the stated range.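

In this assay, chloro in place of hydrogen on an aromatic carbon, between two ring nitrogen atoms, gives a numerical result, with compound 4 at 83200 nM. The change gives an at least 1.2-fold lower number from compound 1 to compound 4 (0.07 log units; that floor lies within the scatter), and its true size stays unresolved because compound 1 sits at a limit of the assay and not at a number: the limit of > 100000 nM in this assay, at which 1 of the 4 values shown sits.

Going by these compounds alone, the only difference between compound 4 and compound 3 is where the chloromethyl group sits on the benzyl ring, and compound 3 gives 5120 nM, so the added chloro group alone does not set the number.

Going by these compounds, it remains open whether an amine or a methoxy group on that same carbon would also give a numerical result. Also open, on these data alone, is whether a plain methyl group could stand in for the chloromethyl group.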